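The source may report more compounds than this note shows. Statements on the series, on what has been measured and on what is new or still open speak of the compounds shown alone.

Among the measured compounds shown here, compound 2 `CCc1ccccc1C(Nc1ccc(Cl)cc1Cl)C(=O)CCc1ccncc1` is the one compound of the pair with a number in an assay on isolated protein for binding affinity to corticotropin-releasing factor receptor 1 (Homo sapiens); on this read-out higher numbers stand for weaker inhibition and lower numbers for stronger inhibition: compound 2 gives 330 nM. Compound 1 `Cc1ccc(C(Nc2ccc(C)cc2Cl)C(=O)CCc2ccncc2)cc1` reaches only the limit of this assay, at which it is recorded as > 10000 nM; that is a limit, not a number (the limit of > 10000 nM in this assay, at which 1 of the 2 values shown sits). Compound 3 `Cc1cccc(C)c1C(Nc1ccc(Cl)cc1Cl)C(=O)CCc1ccncc1` differs from compound 2 in one place: 2,6-dimethylphenyl in place of 2-ethylphenyl on a saturated chain carbon bound to a carbonyl carbon and a nitrogen on an aromatic ring. For the measured compounds named here, no measured pair of compounds traces this change, so the size of the step is open. The expectation is for compound 3 to sit close to compound 2, with the step of a 1.1-fold lower number from compound 2 to compound 3 (0.04 log units; within the scatter) within the usual scatter. Compound 3 is estimated at 300 nM, between 80 nM and 1200 nM.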

Compound 3, inhibition constant: 338 nM
The estimate for compound 3 lay 1.1-fold (0.05 log units) below the measured number; low and high end bracket the measured number.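

In this assay, placing 2,6-dimethylphenyl instead of 2-ethylphenyl on the saturated chain carbon gives a 1.0-fold higher number from compound 2 to compound 3 (0.01 log units; within the scatter): at this position, these two groups, each with 8 carbon atoms and one aromatic ring, read alike. The earlier pair offered no such reading, since compound 1 differs from compound 2 in more than one place. Nothing measured here accounts for the two groups reading alike. Still open, on these data alone, is whether a phenyl ring carrying an amine or a carboxylic acid, or a simple butyl chain with no ring, would keep this level of binding.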